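The source may hold more compounds than are shown below. What is called first, only, known or untested is meant among the compounds shown, and "the series" means these compounds.

Values measured in an ADME assay on MT4 cells (Homo sapiens) for cytotoxicity, with a stated time of 5 days; on this read-out higher numbers stand for lower toxicity in this test and lower numbers for higher toxicity in this test:

- Compound 1 `CC(C)(C)C#Cc1cc(N(C(=O)[C@H]2CC[C@H](C)CC2)[C@H]2CC[C@H](Oc3ccc4nccn4n3)CC2)c(C(=O)O)s1`: 133 nM
- Compound 2 `CC(C)(C)C#Cc1cc(N(C(=O)[C@H]2CC[C@H](C)CC2)[C@H]2CC[C@H](OC3COC3)CC2)c(C(=O)O)s1`: 8350 nM
- Compound 3 `CC(C)(C)C#Cc1cc(N(C(=O)[C@H]2CC[C@H](C)CC2)[C@H]2CC[C@H](OC3CCOCC3)CC2)c(C(=O)O)s1`: 1990 nM

Compound 3 has the second highest of these three numbers, lying under compound 2 and over compound 1. The next compound to consider, compound 4 `CC(C)(C)C#Cc1cc(N(C(=O)[C@H]2CC[C@H](C)CC2)[C@H]2CC[C@H](OC3CCOC3)CC2)c(C(=O)O)s1`, differs from compound 3 in one group: oxolan-3-yl in place of oxan-4-yl on an oxygen on a saturated carbon. A five-membered non-aromatic ring thus replaces a six-membered one, and each holds one hetero atom.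

The most relevant evidence is a 4.2-fold lower number from compound 2 to compound 3 (0.62 log units; beyond the scatter), a modest step beyond the scatter. It links the oxetan-3-yl of compound 2 to the oxan-4-yl of compound 3, the two groups closest to oxolan-3-yl. The steps of a 63-fold higher number from compound 1 to compound 2 (1.80 log units; beyond the scatter) and a 15-fold higher number from compound 1 to compound 3 (1.18 log units; beyond the scatter) are both large, but they remove a much bigger aromatic group, so they say little about this smaller change. Going by the values given here, only two compounds carry a ring of the saturated kind, so any trend in ring size remains tentative.

Since oxolan-3-yl is intermediate in size, compound 4 is expected to fall between compound 3 and compound 2. The expected change is a 1.8-fold higher number from compound 3 to compound 4 (0.25 log units; within the scatter), a modest rise that may not clear the scatter. For compound 4 the estimated value is 3500 nM, with an expected range of 1500 nM to 8500 nM.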

Compound 4, half-maximal cytotoxic concentration: 3070 nM
For compound 4 the middle estimate is 1.1-fold (0.06 log units) above the measured one; measured number inside the range.
By their numbers in this assay, from the lowest: compound 1; then compounds 3 and 4 (each within the scatter of the next); then compound 2.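

In this assay, exchanging the six-membered oxan-4-yl for the five-membered oxolan-3-yl on this oxygen makes no readable difference: a 1.5-fold higher number from compound 3 to compound 4 (0.19 log units; within the scatter) stays within the usual scatter, so compound 3 and compound 4 cannot be told apart. The four-membered oxetan-3-yl of compound 2 does stay separate from the five-membered ring, with a 2.7-fold lower number from compound 2 to compound 4 (0.43 log units; beyond the scatter) beyond the scatter, so the only clear separation among these three saturated rings sets the four-membered ring apart from the two larger ones, and no steady slope with ring size appears. The five-membered ring also stays far from the large aromatic group of compound 1, as a 23-fold higher number from compound 1 to compound 4 (1.36 log units; beyond the scatter) shows, which places compound 4 with the other saturated rings.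

From the compounds shown here alone, it remains open whether a saturated ring carrying an amine nitrogen in place of the ring oxygen, or an open chain such as 2-methoxyethyl, would keep the number at this level. Nothing measured here speaks to what lies behind these differences.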